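This account rests on a few compounds, and the source may have more. Where it says the series, first, only, none or still open, it means among the compounds named here.

In a functional assay on HeLa cells (Homo sapiens) for inhibition, read by sulforhodamine B assay (a higher number here means a weaker inhibitor, a lower number a stronger inhibitor), three compounds sharing one core have been measured. Compound 1 `O=C1C(Nc2ccc(Br)cc2)=CC(=O)c2c1nc1n2[C@H]2OC[C@@H](O)[C@H]2OC1`, which carries a (4-bromophenyl)amino group, gives 5220 nM. Compound 3 `CCOc1ccc(NC2=CC(=O)c3c(nc4n3[C@H]3OC[C@@H](O)[C@H]3OC4)C2=O)cc1` gives 14400 nM, the higher of the two actual numbers in the series. Compound 2 `O=C1C(N2CCCC2)=CC(=O)c2c1nc1n2[C@H]2OC[C@@H](O)[C@H]2OC1` gives > 16000 nM, which is a limit of the assay and not a number.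

Compound 4 `O=C1C(NCc2ccccc2)=CC(=O)c2c1nc1n2[C@H]2OC[C@@H](O)[C@H]2OC1` has yet to be measured. It has benzyl in place of the 4-ethoxyphenyl of compound 3 on an amine nitrogen: benzyl in place of 4-ethoxyphenyl on an amine nitrogen.

Among the measured compounds shown here, two measured steps bear on this change. Ethoxy in place of bromo on an aromatic carbon gave a 2.8-fold higher number from compound 1 to compound 3 (0.44 log units; beyond the scatter), and pyrrolidin-1-yl in place of (4-bromophenyl)amino on a double-bonded ring carbon gave an at least 3.0-fold higher number from compound 1 to compound 2 (0.48 log units; beyond the scatter). Both lie beyond the scatter, but both are modest in size, and both run towards higher numbers. Changes to this substituent have therefore moved the number only modestly so far, and compound 3 already stands high at 14400 nM. No step beyond the scatter is therefore expected in this assay, and any shift is about equally likely to go either way. The estimated change is a 1.4-fold lower number from compound 3 to compound 4 (0.16 log units; within the scatter). For compound 4 the expected value is 10000 nM, with an estimated range from 4000 nM to 16000 nM.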

Compound 4, half-maximal inhibitory concentration: 11000 nM
Estimate against measurement, compound 4: 1.1-fold (0.04 log units) below; measured number inside the range.
By their numbers in this assay, from the lowest: compound 1; then compounds 4 and 3 (each within the scatter of the next). At a limit, above all of these: compound 2.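

In this assay, benzyl in place of 4-ethoxyphenyl on the amine nitrogen gives a 1.3-fold lower number from compound 3 to compound 4 (0.12 log units; within the scatter), so this exchange, which also takes away the hydrogen-bond acceptor of the ethoxy group, separates compound 3 and compound 4 by no more than repeat measurements would. The 4-bromophenyl group of compound 1 stays apart from benzyl, with a 2.1-fold higher number from compound 1 to compound 4 (0.32 log units; beyond the scatter), a modest step that puts compound 1 alone at the low end of the series, while compound 3 and compound 4 sit together. The value of compound 2 is a limit of the assay and not a number, and an at least 1.4-fold lower number from compound 2 to compound 4 (0.16 log units; that floor lies within the scatter) is only a floor within the scatter, so the true size of this step cannot be read because of that limit: the limit of > 16000 nM in this assay, at which 1 of the 4 values shown sits.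

What the compounds shown leave open is whether the lower number of compound 1 belongs to bromo itself, since no chloro or iodo group on the aromatic ring stands beside it. Also open, on these data alone, is whether a bromo group on the benzyl ring of compound 4, or a longer chain such as phenethyl on the amine nitrogen, would move the number beyond the scatter.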